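From methyl to 1-hydroxyethyl on the shared core

The source may report more compounds than this note shows. Statements on the series, on what has been measured and on what is new or still open speak of the compounds shown alone.

In a functional assay on OCI-Ly3 cells (Homo sapiens) for antiproliferative activity (on this read-out higher numbers stand for an effect only at larger amounts of compound and lower numbers for an effect already at smaller amounts), compound 1 (`Cc1c(NC(=O)Nc2cnc(-n3nccn3)c(Cl)c2)cnc2ccc(Br)cc12`) gives 12900 nM and compound 2 (`Cc1c(NC(=O)Nc2cnc(-n3nccn3)c(Cl)c2)cnc2ccccc12`) gives 7170 nM. For the measured compounds named here, compound 2 therefore stands within the scatter of the only other measured compound. Compound 3 (`CC(O)c1c(NC(=O)Nc2cnc(-n3nccn3)c(Cl)c2)cnc2ccccc12`) carries 1-hydroxyethyl in place of methyl on an aromatic carbon, opposite the ring nitrogen: 1-hydroxyethyl in place of methyl on an aromatic carbon. Going by the values given here, the one measured step, a 1.8-fold lower number from compound 1 to compound 2 (0.26 log units; within the scatter), lies within the scatter. It puts hydrogen in place of bromo and leaves the methyl untouched, so it bears only weakly on this change. Among the compounds with values here, no measured pair varies the methyl group, and the data give no firm direction. A small step is expected, a 1.4-fold lower number from compound 2 to compound 3 (0.16 log units; within the scatter), which would not go beyond the scatter. In this assay compound 3 is estimated at 5000 nM, with an expected range from 1000 nM to 20000 nM.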

Compound 3, half-maximal effective concentration: 730 nM
For compound 3 the middle estimate is 6.8-fold (0.84 log units) above the measured one; measured number outside the range, below it.
By their numbers in this assay, from the lowest: compound 3; then compounds 2 and 1 (each within the scatter of the next).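

With 1-hydroxyethyl in place of methyl on this aromatic carbon, opposite the ring nitrogen, this assay shows a 9.8-fold lower number from compound 2 to compound 3 (0.99 log units; beyond the scatter), the first step among these compounds to go beyond the scatter. For the compounds shown here, this position on the shared core therefore responds to the group it carries, a response that the only earlier step, a 1.8-fold lower number from compound 1 to compound 2 (0.26 log units; within the scatter), made at another place on the core, did not show. No measurement at hand accounts for this step.

The compounds shown leave open whether the step follows the oxygen or the added carbon, a question that an ethyl, hydroxymethyl or 1-aminoethyl group at this position would address. They also leave open whether the same change would hold on the bromo core of compound 1, or whether a longer chain carrying a hydroxyl or a carboxylic acid would extend it.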